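Methyl in place of cyano on the terminal pyridyl

This account rests on a few compounds, and the source may have more. Where it says the series, first, only, none or still open, it means among the compounds named here.

Three compounds on one shared core differ only in the aromatic group carried on the phenyl ring. Compound 1 `CCC(C)(C)Cc1c[nH]c(CCc2ccc(-c3ccncc3)cc2)n1` gives 95 nM in a functional assay on HEK293 cells for agonist activity at Bombesin receptor subtype-3 (Homo sapiens), read by luminescence and calcium flux, with a stated time of 10 min; on this read-out lower numbers stand for an effect already at smaller amounts and higher numbers for an effect only at larger amounts of compound. Compound 2 `CCC(C)(C)Cc1c[nH]c(CCc2ccc(-c3cnsc3)cc2)n1` gives 100 nM in this assay, and compound 3 `CCC(C)(C)Cc1c[nH]c(CCc2ccc(-c3cccc(C#N)n3)cc2)n1` gives 95 nM. Compound 3 therefore stands level with compound 1 at the digits shown, the two together the lowest of the three numbers, and its separation from compound 2 is also within the scatter. The measured steps were a 1.1-fold higher number from compound 1 to compound 2 (0.02 log units; within the scatter), no change at the digits printed from compound 1 to compound 3 (within the scatter) and a 1.1-fold lower number from compound 2 to compound 3 (0.02 log units; within the scatter), each of them within the scatter.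

Compound 4 `CCC(C)(C)Cc1c[nH]c(CCc2ccc(-c3cccc(C)n3)cc2)n1` differs from compound 3 in one place: methyl in place of cyano on an aromatic carbon. For the measured compounds named here, none of the measured steps exchanges a cyano for a methyl; all three swap the whole terminal aromatic group, and none of them moved the number beyond the scatter. Within this small set the terminal group has been varied three ways without a shift in the read-out, so compound 4 is expected to land close to compound 3. The step expected is a 1.1-fold higher number from compound 3 to compound 4 (0.02 log units; within the scatter), that is no change beyond the scatter. Compound 4 is estimated at 100 nM, with a range from 40 nM to 250 nM.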

Compound 4, half-maximal effective concentration: 102 nM
Compound 4: the middle estimate sits 1.0-fold (0.01 log units) below what was measured; the measured number falls inside the stated range.
By their numbers in this assay, from the lowest: compounds 1, 3, 2 and 4 (each within the scatter of the next).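

For the compounds shown here, the first exchange confined to a single substituent, rather than the whole terminal aromatic group, gives a 1.1-fold higher number from compound 3 to compound 4 (0.03 log units; within the scatter) in this assay, so at this place next to the ring nitrogen, cyano, with its triple bond and its count as a hydrogen-bond acceptor, can give way to methyl, which has neither, without a shift beyond the scatter. Going by these compounds alone, the 6-methylpyridin-2-yl group also stays level with the other two terminal groups, with a 1.0-fold higher number from compound 2 to compound 4 (0.01 log units; within the scatter) and a 1.1-fold higher number from compound 1 to compound 4 (0.03 log units; within the scatter), so all four terminal groups on the shared core lie within the scatter of one another, and no compound among them goes against this. Nothing measured here bears on why the read-out stays so flat across these changes.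

The compounds shown leave open whether an amine, a carboxylic acid or a longer chain such as propyl at this same place would also stay within the scatter. They also leave open whether the exchange of cyano for methyl would read the same at another carbon of the terminal ring.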